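This account rests on a few compounds, and the source may have more. Where it says the series, first, only, none or still open, it means among the compounds named here.

Compound 1 `COc1ccc(-c2cc(C(=O)/C=C/c3ccccc3)nc3cc(-c4ccccc4)nn23)cc1OC` gives 15600 nM.
Compound 2 `COc1ccc(-c2cc(/C=C/C(=O)c3ccc(C)cc3)nc3cc(-c4ccccc4)nn23)cc1OC` gives 26800 nM.
Compound 3 `COc1ccc(-c2cc(/C=C/C(=O)c3ccc(OC)c(OC)c3)nc3cc(-c4ccccc4)nn23)cc1` gives 16400 nM.

In a functional assay on DU-145 cells (Homo sapiens) for antiproliferative activity, read by MTT assay, with a stated time of 24 h (on this read-out higher numbers stand for weaker inhibition and lower numbers for stronger inhibition), compound 1 has the lowest of the three numbers, yet compound 3 and compound 2 both sit within the usual scatter of it. Compound 4 `COc1ccc(C(=O)/C=C/c2cc(-c3ccc(OC)c(OC)c3)n3nc(-c4ccccc4)cc3n2)cc1` is not yet measured; it differs from compound 1 in one place: 2-((4-methoxyphenyl)carbonyl)ethenyl in place of (2-phenylethenyl)carbonyl on an aromatic carbon. One measured step is of the same kind, swapping the order of the carbonyl and the ethenyl while a substituent is added to the outer ring: a 1.7-fold higher number from compound 1 to compound 2 (0.24 log units; within the scatter). Compound 3, which also carries the swapped arrangement, gives a number indistinguishable from compound 1. Nothing among these compounds points to a shift in this assay beyond the scatter. Compound 4 is therefore expected near 19000 nM, between 8000 nM and 45000 nM. The expected step is a 1.2-fold higher number from compound 1 to compound 4 (0.09 log units; within the scatter).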

Compound 4, half-maximal inhibitory concentration: 14600 nM
Estimate against measurement, compound 4: 1.3-fold (0.11 log units) above; the measured number falls inside the stated range.
By their numbers in this assay, from the lowest: compounds 4, 1, 3 and 2 (each within the scatter of the next).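

In this assay, placing 2-((4-methoxyphenyl)carbonyl)ethenyl on this aromatic carbon in place of (2-phenylethenyl)carbonyl does not separate compound 4 from its parent (a 1.1-fold lower number from compound 1 to compound 4 (0.03 log units; within the scatter)). Methoxy in place of methyl on the outer ring does not separate the compounds either (a 1.8-fold lower number from compound 2 to compound 4 (0.26 log units; within the scatter)), so both changes leave the antiproliferative read-out within the scatter. Nothing available explains this flat result.

From the compounds shown here alone, whether an amine or a carboxylic acid on that outer ring would shift the number beyond the scatter remains open. So does the effect of a longer chain in place of the methoxy.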